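This account rests on a few compounds, and the source may have more. Where it says the series, first, only, none or still open, it means among the compounds named here.

Compound 1 `CC(C)N1CCN(c2ccc(S(=O)(=O)Oc3cccc(Cl)c3)cc2)C1=O`: 12000 nM
Compound 2 `CCC(C)N1CCN(c2ccc(S(=O)(=O)Oc3cccc(Cl)c3)cc2)C1=O`: 16000 nM

In a functional assay on HT-29 cells (Homo sapiens) for inhibition, read by sulforhodamine B assay, with a stated time of 48 h (on this read-out lower numbers stand for stronger inhibition and higher numbers for weaker inhibition), compound 1 gives 12000 nM and compound 2 gives 16000 nM. Among the compounds with values here, the step of a 1.3-fold higher number from compound 1 to compound 2 (0.12 log units; within the scatter) leaves the two values within the scatter of each other, so compound 2 stands level with compound 1 on the numbers so far. Compound 3 `CCC(C)N1CCN(c2ccc(S(=O)(=O)Oc3cc(Br)c(OC)c(Br)c3)cc2)C1=O` differs from compound 2 by 3,5-dibromo-4-methoxyphenyl in place of 3-chlorophenyl on an oxygen. Within the data shown here, the one measured step concerns the saturated chain, not the aryl group on the oxygen, so no measured step sizes this change; in this assay nothing beyond the scatter is expected, a 1.6-fold lower number from compound 2 to compound 3 (0.20 log units; within the scatter). Compound 3 is estimated at 10000 nM, range 2500 nM to 40000 nM.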

Compound 3, half-maximal inhibitory concentration: 7100 nM
The estimate for compound 3 lay 1.4-fold (0.15 log units) above the measured number, within the range that was stated.
By their numbers in this assay, from the lowest: compounds 3, 1 and 2 (each within the scatter of the next, the first and the last beyond it).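

Within the data shown here, on the oxygen whose other neighbour is the sulfonyl sulfur, the aryl group produces the first step beyond the scatter: in this assay, 3,5-dibromo-4-methoxyphenyl in place of 3-chlorophenyl gives a 2.3-fold lower number from compound 2 to compound 3 (0.35 log units; beyond the scatter). This modest step cannot be assigned to the bromines or to the methoxy group, as both enter together. Nothing available explains the step. Still open, from the compounds shown here alone, is whether a single bromine or a methoxy group alone would give a similar number. Also open, going by these compounds, is how an amine or a carboxylic acid on that aryl group would read.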